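This account rests on a few compounds, and the source may have more. Where it says the series, first, only, none or still open, it means among the compounds named here.

In a functional assay on BXPC-3 cells (Homo sapiens) for cytotoxicity, read by fluorescence, with a stated time of 48 h (a lower number here means that less compound is needed, a higher number that more compound is needed for the effect), only two close relatives have been tested so far. Within the data shown here, compound 1 `CC(C)=CCC/C(C)=C/CC/C(C)=C/CSC[C@H](NC(=O)CCCCCN1CCN(C)CC1)C(=O)NC1CC1` gives 6300 nM, the only true number available, so there is no measured series to rank it in. Compound 2 `CC(C)=CCC/C(C)=C/CC/C(C)=C/CSC[C@H](NC(=O)CCCCCN1CCCC1)C(=O)NC1CC1` gives > 20000 nM, and this value is a limit of the assay, not a number. Putting pyrrolidin-1-yl in place of 4-methylpiperazin-1-yl produced an at least 3.1-fold higher number from compound 1 to compound 2 (0.50 log units; beyond the scatter), a step beyond the scatter.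

Compound 3 `CC(C)=CCC/C(C)=C/CC/C(C)=C/CSC[C@H](NC(=O)CCCCCN1CCN(C)CC1)C(=O)NC1CCCCC1` keeps the 4-methylpiperazin-1-yl group of compound 1 and changes a different group: cyclohexyl in place of cyclopropyl on an amide-type nitrogen. In words, cyclohexyl takes the place of cyclopropyl on an amide-type nitrogen. Among the measured compounds shown here, the single measured step, an at least 3.1-fold higher number from compound 1 to compound 2 (0.50 log units; beyond the scatter), lies elsewhere in the molecule, so it bears on this change only indirectly. It shows that swapping one group in this series can shift the read-out, but it gives no direction for this swap. The expected change is small and only tentatively toward a lower number, a 1.6-fold lower number from compound 1 to compound 3 (0.20 log units; within the scatter), which would not clearly exceed the scatter. For compound 3 the estimated value is 4000 nM, with an expected range of 1500 nM to 12000 nM.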

Compound 3, half-maximal effective concentration: 12000 nM
Compound 3: middle estimate off by 3.0-fold (0.48 log units), on the low side; measured number inside the range.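

At this amide-type nitrogen, cyclohexyl in place of cyclopropyl gives a 1.9-fold higher number from compound 1 to compound 3 (0.28 log units; within the scatter) in this assay, so the two compounds cannot be told apart in this assay. Going from a three-membered to a six-membered carbon ring therefore leaves the read-out within the usual scatter, unlike the change at the other end of the molecule, an at least 3.1-fold higher number from compound 1 to compound 2 (0.50 log units; beyond the scatter), which goes beyond it. Of the compounds shown, only compound 2 sits at a limit of the assay rather than at a true number, while compound 3 stays on the measurable scale: the limit of > 20000 nM in this assay, at which 1 of the 3 values shown sits.

Two ring sizes say little about other groups on this nitrogen, such as a methyl, a tert-butyl or a phenyl ring, or about a cyclohexyl ring carrying a hydroxyl or an amine. It also remains open whether cyclohexyl would behave in the same way in a compound carrying pyrrolidin-1-yl in place of 4-methylpiperazin-1-yl, since the two changes appear together in none of the compounds shown.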